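This account rests on a few compounds, and the source may have more. Where it says the series, first, only, none or still open, it means among the compounds named here.

Measured so far:
compound 1, `C#CCN(C)Cc1cn(-c2cc(NC(=S)NCC)ncn2)cn1` — > 50000 nM
compound 2, `C#CCN1CCN(Cc2cn(-c3cc(NC(=S)NCC)ncn3)cn2)CC1` — > 50000 nM

In an assay on isolated protein for inhibition of Amine oxidase [flavin-containing] A (Homo sapiens), read by fluorescence and Amplex Red, with a stated time of 15 min (on this read-out lower numbers stand for stronger inhibition and higher numbers for weaker inhibition), compound 2 reaches only a limit of the assay, > 50000 nM, not a number. Compound 1 likewise stops at a limit, > 50000 nM. Going by the values given here, the one measured step, a step that the two limits leave unreadable from compound 1 to compound 2, therefore cannot be read, and the gathered evidence is only (the limit of > 50000 nM in this assay, at which 2 of the 2 values shown sit).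

Compound 3, `C#CCNCCCc1cn(-c2cc(NC(=S)NCC)ncn2)cn1`, is the next compound. It differs from compound 2 by 2-(propargylamino)ethyl in place of 4-propargylpiperazin-1-yl on a saturated chain carbon bound to an aromatic carbon. Among the compounds with values here, no readable step bears on this change, so its size cannot be taken from the data, and the two values so far give no direction at all.

Given that both values sit at the limit of > 50000 nM in this assay, at which 2 of the 2 values shown sit, compound 3 is expected to land at or near the limit as well, with its value in this assay estimated at 80000 nM, in the range 20000 nM to 400000 nM. The step this estimate means, a step that the limit leaves unreadable from compound 2 to compound 3, is expected to stay within scatter.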

Compound 3, half-maximal inhibitory concentration: > 50000 nM
Compound 3 gave a limit, no number (the forecaster's own chance of this, stated with the estimate: 80%); the middle value is on the limit's open side.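

Compound 3 stops at a limit in this assay, > 50000 nM, not a number. Its steps from compound 1 and compound 2 therefore cannot be read. The compounds shown leave open whether these side chains differ in inhibition at all: the limit of > 50000 nM in this assay, at which 3 of the 3 values shown sit.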